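The source may report more compounds than this note shows. Statements on the series, on what has been measured and on what is new or still open speak of the compounds shown alone.

Working notes on a small series tested in an assay on HEK293 cells for activation of potassium channel subfamily T member 1 (Homo sapiens), read by thallium flux; on this read-out higher numbers stand for an effect only at larger amounts of compound and lower numbers for an effect already at smaller amounts.

Compound 1 `COc1ccc(NC(=O)CN2CCN(S(=O)(=O)N3CCC(C)CC3)CC2)cc1` carries a methoxy on the outer aromatic ring. In this assay compound 1 gives > 10000 nM, which is a limit of the measurement and not a number. What is known of compound 1 comes down to the limit of > 10000 nM in this assay, at which 1 of the 2 values shown sits. Going by the values given here, the related compound 2 `COc1ccc(Cl)cc1NC(=O)N1CCC2(CC1)CN(S(=O)(=O)N1CCC(C)CC1)C2`, built on a different core, gives 10000 nM in this assay; no step between compound 1 and compound 2 is counted, so the two values are only set side by side.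

Compound 3 `CC1CCN(S(=O)(=O)N2CCN(CC(=O)Nc3ccc(F)cc3)CC2)CC1` is not yet measured. It differs from compound 1 by fluoro in place of methoxy on an aromatic carbon. Among the compounds with values here, no measured step of this kind exists, so nothing shows its direction. Given that compound 1 sits at the limit, the expected step of a number no higher from compound 1 to compound 3 (the limit leaves the size open) is none beyond the scatter. Compound 3 is expected to give about 10000 nM, with a range from 3000 nM to 30000 nM, and a limit is again the likelier outcome.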

Compound 3, half-maximal effective concentration: > 10000 nM
Compound 3: only a limit was reported (the forecaster's own chance of this, stated with the estimate: 60%); the middle value sits exactly at the limit.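

No step between compound 1 and compound 3 can be read, as each gives only a limit of the measurement and not a number: the limit of > 10000 nM in this assay, at which 2 of the 3 values shown sit.

The compounds shown leave open whether fluoro in place of methoxy on an aromatic carbon shifts the value at all in this assay.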